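Aryl swap on the ring nitrogen: compound 4 estimate

A few compounds are considered here, and "the series" means these few. Any claim that something is new, unique, unknown or untested is made for them only; others in the source may bear on it.

Compound 1 `Nc1scc(CN2CCN(c3cccc(C(F)(F)F)c3)CC2)c1C(=O)c1ccc(Cl)cc1` gives -80% in a functional assay on CHO cells with adenosine receptor A1 (Homo sapiens) as the target, read by cAMP accumulation and immunoassay, with a stated time of 6 min, tested at 10 uM (on this read-out higher numbers stand for a weaker effect at the one concentration tested and lower numbers for a stronger effect), the lowest of the three numbers in hand. Compound 2 `Nc1scc(CN2CCN(c3cccc(F)c3)CC2)c1C(=O)c1cccc(C(F)(F)F)c1` differs from compound 1 in two places; in this assay compound 2 gives -62%. Compound 3 `Nc1scc(CN2CCN(c3cccc4ccccc34)CC2)c1C(=O)c1ccc(Cl)cc1` gives -21%. Among the measured compounds shown here, the only single-point step measured, a number 59 percentage points higher from compound 1 to compound 3 (beyond the scatter), is large and runs toward a weaker effect. Compound 4 `Nc1scc(CN2CCN(c3cccc(F)c3F)CC2)c1C(=O)c1ccc(Cl)cc1` carries the change (2,3-difluorophenyl in place of 3-(trifluoromethyl)phenyl on an amine nitrogen in a ring). Here the entering group has fewer heavy atoms than the leaving one, whereas compound 3 took on a larger group, so that step bears on compound 4 only loosely; a modest rise or none beyond the scatter is expected. Compound 4 is therefore estimated at -60%, range -88% to -20%, an expected step of a number 20 percentage points higher from compound 1 to compound 4 (beyond the scatter).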

Compound 4, a percentage reported as activity, at one concentration (the size of the read-out at that concentration, not a potency): -79%
The estimate for compound 4 lay 19 percentage points above the measured number; the range from low to high includes it.
By their numbers in this assay, from the lowest: compounds 1 and 4 (each within the scatter of the next); then compound 2; then compound 3.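

In this assay, the amine nitrogen in the ring takes 2,3-difluorophenyl in place of 3-(trifluoromethyl)phenyl with no change beyond the scatter (a number 1 percentage points higher from compound 1 to compound 4 (within the scatter)), even though the entering group has fewer heavy atoms. The weak read-out of compound 3 therefore does not extend to every replacement at this position, as the large gap to naphthalen-1-yl shows (a number 58 percentage points lower from compound 3 to compound 4 (beyond the scatter)). No evidence in hand accounts for this difference between the aryl groups.

Still open, on these data alone, is whether a pyridine ring or a phenyl bearing a methoxy group would stay level with compound 1 and compound 4 at this nitrogen. As far as these compounds go, whether a second fused ring at another attachment point gives the same weak read-out as naphthalen-1-yl also remains open.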